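This account rests on a few compounds, and the source may have more. Where it says the series, first, only, none or still open, it means among the compounds named here.

In a functional assay on NCI-H460 cells (Homo sapiens) for cytotoxicity, read by MTT assay, with a stated time of 72 h (on this read-out higher numbers stand for weaker inhibition and lower numbers for stronger inhibition), compound 2 `O=c1[nH]/c(=C\c2c[nH]cn2)c(=O)[nH]/c1=C\c1cccc(Oc2ccc(F)cc2)c1` gives 479 nM and holds the higher of the two numbers, while compound 1 `Cc1[nH]cnc1/C=c1\[nH]c(=O)/c(=C/c2cccc(Oc3ccc(F)cc3)c2)[nH]c1=O` gives 47.6 nM as the lower. Among the measured compounds shown here, the only measured step is a 10-fold higher number from compound 1 to compound 2 (1.00 log units; beyond the scatter) and it touches the same imidazole group that now leaves. For the measured compounds named here, compound 3 `O=c1[nH]/c(=C\c2cccc(Oc3ccc(F)cc3)c2)c(=O)[nH]/c1=C\c1cccnc1` carries pyridin-3-yl in place of 1H-imidazol-4-yl on a double-bonded chain carbon bound to an aromatic carbon and no measured step covers this swap. A modest further rise is therefore expected, with a 1.5-fold higher number from compound 2 to compound 3 (0.16 log units; within the scatter) as the estimated step in this assay and wide uncertainty. Compound 3 is estimated at 700 nM with 170 nM to 3000 nM as the expected range.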

Compound 3, half-maximal inhibitory concentration: > 1000 nM
Compound 3 was reported as a limit (the forecaster's own chance of this, stated with the estimate: 8%); middle value at least 1.4-fold (0.15 log units) away from the limit.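

In this assay, the swap of the ring itself gives an at least 2.0-fold higher number from compound 2 to compound 3 (0.31 log units; beyond the scatter), and set against the methylated imidazole it gives an at least 21-fold higher number from compound 1 to compound 3 (1.32 log units; beyond the scatter). This place on the double-bonded chain carbon therefore responds to replacing the whole imidazole, not only to a methyl on it. Compound 3 stands only as a limit, so the full size of both steps cannot be read: the limit of > 1000 nM in this assay, at which 1 of the 3 values shown sits.

The compounds shown cannot separate the change of ring size from the hydrogen-bond donor that leaves. As far as these compounds go, how a pyrazole, or a methyl on the pyridin-3-yl ring, would read here also stays open.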